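This account rests on a few compounds, and the source may have more. Where it says the series, first, only, none or still open, it means among the compounds named here.

Three compounds of the series have been compared in a functional assay on the whole organism with Mus musculus as the target; a higher number here means that more compound is needed for the effect, a lower number that less compound is needed. Compound 1 `CCCCCOc1ccc2nncn2n1` gives 39.4 mg/kg in this assay. Compound 2 `CCCCCCCCOc1ccc2nncn2n1` yields no number, only a limit of this assay, > 100 mg/kg. Compound 3 `Cc1ccccc1Oc1ccc2nncn2n1` gives 54.8 mg/kg in this assay.

Among the two numbers in hand, compound 3 sits highest, with compound 1 nearest; the gap between them lies within the scatter, so no order between the two is claimed. The third value, that of compound 2, is a limit rather than a number: the limit of > 100 mg/kg in this assay, at which 1 of the 3 values shown sits.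

Going by the values given here, the only measured step is an at least 2.5-fold higher number from compound 1 to compound 2 (0.40 log units; beyond the scatter); it concerns the length of the saturated chain and nothing on an aromatic ring.

Compound 4 `COc1ccccc1Oc1ccc2nncn2n1` differs from compound 3 by methoxy in place of methyl on an aromatic carbon. Among the compounds with values here, no measured step concerns an exchange on the aromatic ring of the substituent, and the step from compound 1 to compound 2 does not bear on this change. With nothing to weigh for or against, no shift beyond the scatter is expected, and the step estimated for compound 4 is a 1.0-fold higher number from compound 3 to compound 4 (0.00 log units; within the scatter). Compound 4 is therefore expected to give about 55 mg/kg in this assay, within a range from 25 mg/kg to 120 mg/kg.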

Compound 4, dose for half-maximal effect: > 100 mg/kg
Compound 4: no number, only a limit; the forecaster's own chance of this, stated with the estimate: 15%; middle value at least 1.8-fold (0.25 log units) away from the limit.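

In this assay compound 4 gives only a limit, > 100 mg/kg, not a number. Methoxy in place of methyl on an aromatic carbon, ortho to a large group, can therefore be read only as a floor, an at least 1.8-fold higher number from compound 3 to compound 4 (0.26 log units; that floor lies within the scatter); the true size of the step may be larger, but what is in hand does not place it beyond the scatter. This is the first measured exchange on the aromatic ring of the substituent, and it shows that a single change at this place, not only the longer saturated chain of compound 2, can reach the limit of the assay: the limit of > 100 mg/kg in this assay, at which 2 of the 4 values shown sit.

Still open, on these data alone, is how large the step from methyl to methoxy really is, since the value of compound 4 has no number to set against that of compound 3. Also open, as far as these compounds go, is whether the outcome at this place belongs to methoxy alone or extends to other groups on the same aromatic carbon, such as a chloro group, an ethoxy group or an amine, any of which could separate a change tolerated here from one that is not.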